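The compounds below may be only part of what the source reports. "The series", "measured", "known", "first", "only" and "open" are said of these compounds alone.

Values in a functional assay on HL-60 cells (Homo sapiens) for cytotoxicity, read by WST assay, with a stated time of 48 h; on this read-out higher numbers stand for weaker inhibition and lower numbers for stronger inhibition:
- Compound 1 `COc1cc(C(c2ccc(O)c(OC)c2)[C@@H](C)[C@@H](C)CO)ccc1O`: > 100000 nM (a limit of the assay)
- Compound 2 `COc1cc(C(c2ccc(O)c(OC)c2)[C@H](CF)C(C)C)ccc1O`: 19000 nM
- Compound 3 `COC[C@@H](C)[C@@H](C)C(c1ccc(O)c(OC)c1)c1ccc(O)c(OC)c1`: 85000 nM

Of the two actual numbers, compound 3 holds the higher, 85000 nM. Compound 4 `COc1cc(C(c2ccc(O)c(OC)c2)[C@@H](C)[C@H](C)CF)ccc1O` carries 2-(fluoromethyl)-1-methylpropyl in place of 2-(methoxymethyl)-1-methylpropyl on a saturated chain carbon bound to two aromatic carbons. The closest guide is compound 2, with its 1-(fluoromethyl)-2-methylpropyl chain, which gives a 4.5-fold higher number from compound 2 to compound 3 (0.65 log units; beyond the scatter). The step of an at least 5.2-fold lower number from compound 1 to compound 2 (0.72 log units; beyond the scatter) points the same way, whereas an at least 1.1-fold lower number from compound 1 to compound 3 (0.07 log units; that floor lies within the scatter) stays within the scatter. A modest move to a lower number is therefore expected, estimated as a 3.4-fold lower number from compound 3 to compound 4 (0.53 log units; beyond the scatter). Compound 4 is expected at 25000 nM, with an estimated range of 10000 nM to 70000 nM.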

Compound 4, half-maximal inhibitory concentration: 32000 nM
For compound 4 the middle estimate is 1.3-fold (0.11 log units) below the measured one; the measured number falls inside the stated range.
By their numbers in this assay, from the lowest: compounds 2 and 4 (each within the scatter of the next); then compound 3. At a limit, above all of these: compound 1.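

In this assay, on a saturated chain carbon bound to two aromatic carbons, 2-(fluoromethyl)-1-methylpropyl gives a 2.7-fold lower number from compound 3 to compound 4 (0.42 log units; beyond the scatter), so a second fluorinated chain, beside that of compound 2, also stands below the methoxymethyl chain of compound 3. The two fluorinated chains cannot be told apart, with a 1.7-fold higher number from compound 2 to compound 4 (0.23 log units; within the scatter). Against the hydroxymethyl chain the result is an at least 3.1-fold lower number from compound 1 to compound 4 (0.49 log units; beyond the scatter), and that step rests on the limit of compound 1: the limit of > 100000 nM in this assay, at which 1 of the 4 values shown sits.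

The compounds shown leave open whether an amine, a carboxylic acid or a longer chain in place of the fluoromethyl end would give a lower number than the fluorinated chains.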